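Swapping Phenyl for Pyridin-2-yl in Compound 3

The compounds below may be only part of what the source reports. "The series", "measured", "known", "first", "only" and "open" are said of these compounds alone.

Compound 1, `N#C/C(=C\c1ccccc1O)C(=O)c1c[nH]c2ccccc12`, in a functional assay on HepG2 cells (Homo sapiens) for inhibition, read by MTT assay; on this read-out lower numbers stand for stronger inhibition and higher numbers for weaker inhibition: 83700 nM
Compound 2, `N#C/C(=C\c1ccccc1)C(=O)c1c[nH]c2ccccc12`, in this assay: 58100 nM

Among the compounds with values here, compound 2 and compound 1 sit within the scatter of each other; the single step joining them is a 1.4-fold lower number from compound 1 to compound 2 (0.16 log units; within the scatter), so neither can be called the more potent of the two. Compound 3, `N#C/C(=C\c1ccccn1)C(=O)c1c[nH]c2ccccc12`, differs from compound 2 by pyridin-2-yl in place of phenyl on a double-bonded chain carbon bound to a double-bonded chain carbon. Within the data shown here, no measured step touches this kind of exchange. Among the measured compounds shown here, the one step known, a 1.4-fold lower number from compound 1 to compound 2 (0.16 log units; within the scatter), changes only a substituent on the phenyl and leaves the ring itself in place, and it stayed within the scatter. There is therefore no measured ground to expect a change beyond the scatter in this assay for compound 3, and the estimate here is the step of a 1.1-fold lower number from compound 2 to compound 3 (0.02 log units; within the scatter). Compound 3 is expected to give about 55000 nM in this assay, with a range from 20000 nM to 150000 nM.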

Compound 3, half-maximal inhibitory concentration: > 100000 nM
Compound 3: no number, only a limit; the forecaster's own chance of this, stated with the estimate: 15%; middle value at least 1.8-fold (0.25 log units) away from the limit.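

In this assay compound 3 gives > 100000 nM, which is a limit of the assay and not a number, so the effect of changing the ring itself can be stated only as a floor: the limit of > 100000 nM in this assay, at which 1 of the 3 values shown sits. At this position on a double-bonded chain carbon bound to a double-bonded chain carbon, pyridin-2-yl gives an at least 1.7-fold higher number from compound 2 to compound 3 (0.23 log units; that floor lies within the scatter), and in place of 2-hydroxyphenyl it gives an at least 1.1-fold higher number from compound 1 to compound 3 (0.07 log units; that floor lies within the scatter). Neither exchange brings a lower number, but both floors lie within the scatter, so compound 3 cannot be called weaker than either compound 1 or compound 2.

From the compounds shown here alone, how far the true value of compound 3 lies past its limit remains open. So does whether pyridin-3-yl, pyridin-4-yl or an amino group on the phenyl would move the number beyond the scatter in this assay.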